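What happens when the amino chain leaves compound 2?

This account rests on a few compounds, and the source may have more. Where it says the series, first, only, none or still open, it means among the compounds named here.

Among the measured compounds shown here, in an ADME assay on L02 cells (Homo sapiens) for antiproliferative activity, read by MTT assay, with a stated time of 48 h (on this read-out lower numbers stand for stronger inhibition and higher numbers for weaker inhibition), compound 2 (`CCn1c(C(=O)NCCN)ccc1C(CC)(CC)c1ccc(OCCC(O)(CC)CC)c(C)c1`) gives 2940 nM, the only exact number so far. Compound 1 (`CCn1c(C(=O)NCC#N)ccc1C(CC)(CC)c1ccc(OCCC(O)(CC)CC)c(C)c1`) gives > 50000 nM, which is a limit of the assay and not a number. For the measured compounds named here, the one measured step is an at least 17-fold lower number from compound 1 to compound 2 (1.23 log units; beyond the scatter), and it is large. Compound 3 (`C#CCCOC(=O)c1ccc(C(CC)(CC)c2ccc(OCCC(O)(CC)CC)c(C)c2)n1CC`) carries (but-3-yn-1-yl)oxy in place of (2-aminoethyl)amino on a carbonyl carbon. Going by the values given here, this takes away the chain end that compound 2 has and compound 1 lacks, so the single step of an at least 17-fold lower number from compound 1 to compound 2 (1.23 log units; beyond the scatter) suggests a large move back toward higher numbers in this assay, meaning weaker inhibition. That expectation rests on one step only. The expected change is an 8.5-fold higher number from compound 2 to compound 3 (0.93 log units; beyond the scatter). For compound 3 the estimated value is 25000 nM, with an expected range of 8000 nM to 50000 nM.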

Compound 3, half-maximal inhibitory concentration: > 50000 nM
Compound 3 was reported as a limit (the forecaster's own chance of this, stated with the estimate: 45%); at least 2.0-fold (0.30 log units) between middle value and limit.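

On a carbonyl carbon, exchanging (2-aminoethyl)amino for (but-3-yn-1-yl)oxy in this assay gives an at least 17-fold higher number from compound 2 to compound 3 (1.23 log units; beyond the scatter). Among the compounds shown here, until now, only a nitrile-ended chain had been set against the amine-ended chain, so this is the second replacement without the amine, and this time the amide nitrogen goes too; among the three compounds, only the one with (2-aminoethyl)amino gives an exact number. Compound 1 and compound 3 cannot be ordered, and their step cannot be read, because each is reported only as a limit: the limit of > 50000 nM in this assay, at which 2 of the 3 values shown sit.

From the compounds shown here alone, it stays open whether the amine itself or the whole (2-aminoethyl)amino chain goes with the lower number. A longer chain ending in an amine, or a chain of the same length ending in a hydroxyl, would help to separate the two.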